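The source may report more compounds than this note shows. Statements on the series, on what has been measured and on what is new or still open speak of the compounds shown alone.

Going by the values given here, compound 2 `Fc1cc(Cl)ccc1-c1ccc(Cn2nnc3ccccc32)cc1` gives 1.1 mL/min/g in an ADME assay on microsomes from liver (Mus musculus, strain NMRI) for metabolic stability, tested at 2.5 uM (a lower number here means slower removal, a higher number faster removal of the compound), the lowest of the two numbers measured so far. Its nearest neighbour is compound 1 `c1ccc(-c2ccc(Cn3nnc4ccccc43)cc2)cc1`, which in this assay gives 11.4 mL/min/g; the step of a 10-fold lower number from compound 1 to compound 2 (1.02 log units; beyond the scatter) is large, a change in which 4-chloro-2-fluorophenyl stands in place of phenyl on an aromatic carbon. Compound 3 `Fc1ccc(-c2ccc(Cn3nnc4ccccc43)cc2)c(Cl)c1` has not yet been measured in this assay. It differs from compound 2 by 2-chloro-4-fluorophenyl in place of 4-chloro-2-fluorophenyl on an aromatic carbon. Among the compounds with values here, the one measured step, a 10-fold lower number from compound 1 to compound 2 (1.02 log units; beyond the scatter), shows how strongly the arrival of the two halogens lowered the number, but no measured pair tells what exchanging the places of chlorine and fluorine does, since compound 2 and compound 3 hold the same atoms joined differently. With both halogens kept on the ring, the expected step is a 1.4-fold higher number from compound 2 to compound 3 (0.13 log units; within the scatter), most likely within the scatter and without a clear direction. Compound 3 is therefore estimated at 1.5 mL/min/g in this assay, with a range from 0.6 mL/min/g to 4 mL/min/g.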

Compound 3, intrinsic clearance in a liver preparation (reported as CLH), per the amount of preparation that the assay uses: 1.5 mL/min/g
The estimate for compound 3 equals the measured number at the digits printed; the measured number falls inside the stated range.
By their numbers in this assay, from the lowest: compounds 2 and 3 (each within the scatter of the next); then compound 1.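

In this assay, exchanging the places of chlorine and fluorine on the outer ring gives a 1.4-fold higher number from compound 2 to compound 3 (0.13 log units; within the scatter), so compounds 2 and 3 cannot be told apart in this read-out, and this is something the earlier pair could not show. The comparison with the unsubstituted phenyl of compound 1 now exists for a second halogen arrangement, with 2-chloro-4-fluorophenyl giving a 7.6-fold lower number from compound 1 to compound 3 (0.88 log units; beyond the scatter), so among the compounds shown the low number is not confined to 4-chloro-2-fluorophenyl. Nothing available explains why these two arrangements behave alike or why either differs from phenyl.

It remains open whether the low number needs both halogens, as a phenyl carrying chlorine alone or fluorine alone is not among the compounds shown, and whether other arrangements of the two halogens on this ring would fall in the same range. Also open, on these data alone, is how a different substituent on this ring, such as a methoxy, a nitrile, a trifluoromethyl, an amine or a carboxylic acid, would compare with the two halogens in this assay.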